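The compounds below may be only part of what the source reports. "The series", "measured", "known", "first", "only" and "open" are said of these compounds alone.

Measured so far in a functional assay on HOP-62 cells (Homo sapiens) for cytotoxicity, read by sulforhodamine B assay, with a stated time of 48 h, tested at 10 uM; on this read-out higher numbers stand for a weaker effect at the one concentration tested and lower numbers for a stronger effect:
- compound 1, `COc1cc(-c2cc(/C=C/C(=O)c3ccc(Cl)c(Cl)c3)[nH]n2)cc(OC)c1OC`: -9%
- compound 2, `COc1ccc(C(=O)/C=C/c2cc(-c3cc(OC)c(OC)c(OC)c3)n[nH]2)cc1OC`: -97%

Compound 2 stands lowest of the two numbers, the step of a number 88 percentage points lower from compound 1 to compound 2 (beyond the scatter) being beyond the scatter. Compound 3, `COc1cc(C(=O)/C=C/c2cc(-c3cc(OC)c(OC)c(OC)c3)n[nH]2)cc(OC)c1OC`, differs from compound 2 by methoxy in place of hydrogen on an aromatic carbon. Going by the values given here, no measured step covers this change; the only step, a number 88 percentage points lower from compound 1 to compound 2 (beyond the scatter), concerns a different exchange on the carbonyl carbon. Compound 2 already sits near the bottom of the scale, so for compound 3 a step of a number 4 percentage points higher from compound 2 to compound 3 (within the scatter) is expected, none beyond the scatter. Compound 3 is estimated at -93%, between -100% and -75%.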

Compound 3, a percentage reported as activity, at one concentration (the size of the read-out at that concentration, not a potency): -91%
Estimate against measurement, compound 3: 2 percentage points below; measured number inside the range.
By their numbers in this assay, from the lowest: compounds 2 and 3 (each within the scatter of the next); then compound 1.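

In this assay, methoxy in place of hydrogen on this aromatic carbon, ortho to a methoxy group and meta to a large group, gives a number 6 percentage points higher from compound 2 to compound 3 (within the scatter) and so leaves the read-out where it was. Going by these compounds alone, the one earlier step exchanged a whole 3,4-dichlorophenyl for 3,4-dimethoxyphenyl and could not speak for this single position. Nothing measured here explains the result. Still open, from the compounds shown here alone, is whether a larger alkoxy chain, an amine or a carboxylic acid at this position would be tolerated equally well.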